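The source may hold more compounds than are shown below. What is called first, only, known or untested is meant among the compounds shown, and "the series" means these compounds.

Compound 1 `COc1ccc(N(C)c2nc(C)nc3ccccc23)cc1C(=O)NCC[Se]C#N`: 1250 nM
Compound 2 `C[Se]c1ccc(N(C)c2nc(C3CC3)nc3ccccc23)cc1`: 18 nM
Compound 3 `COc1ccc(N(C)c2nc(C)nc3ccccc23)cc1OCCCCC[Se]C#N`: 4410 nM

In a functional assay on MDA-MB-231 cells (Homo sapiens) for inhibition, read by MTT assay, with a stated time of 48 h (on this read-out higher numbers stand for weaker inhibition and lower numbers for stronger inhibition), compound 1 stands second highest of the three numbers; compound 3 sits above it, and compound 2 sits far below it. Compound 4 `COc1ccc(N(C)c2nc(C)nc3ccccc23)cc1OCCC[Se]C#N` differs from compound 1 in one place: a group of 7 heavy atoms (4 carbon, 1 nitrogen, 1 oxygen, 1 selenium; no ring) in place of a group of 8 heavy atoms (4 carbon, 2 nitrogen, 1 oxygen, 1 selenium; no ring), on an aromatic carbon. Among the compounds with values here, one measured step bears on this: the one from compound 1 to compound 3, a 3.5-fold higher number from compound 1 to compound 3 (0.55 log units; beyond the scatter), where a group of 9 heavy atoms replaced the same group of 8 heavy atoms that leaves here. Compound 4 takes a smaller group of 7 heavy atoms in that place, so a rise beyond the scatter is expected, though a more modest one. The step from compound 1 to compound 4 is estimated as a 2.0-fold higher number from compound 1 to compound 4 (0.30 log units; within the scatter). Compound 4 is expected to give about 2500 nM, within 1000 nM to 6000 nM.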

Compound 4, half-maximal inhibitory concentration: 815 nM
Compound 4: middle estimate off by 3.1-fold (0.49 log units), on the high side, and the stated range ends above it.
By their numbers in this assay, from the lowest: compound 2; then compounds 4 and 1 (each within the scatter of the next); then compound 3.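

In this assay, the group of 7 heavy atoms, with 0 hydrogen-bond donors, replaces the group of 8 heavy atoms, with 1 hydrogen-bond donor, on the aromatic carbon and gives only a 1.5-fold lower number from compound 1 to compound 4 (0.19 log units; within the scatter). On the saturated chain, a shorter group in place of a longer one gives a 5.4-fold lower number from compound 3 to compound 4 (0.73 log units; beyond the scatter), so among these compounds the change in chain length moves the number beyond the scatter. No measured evidence accounts for either step. The compounds shown leave open how a still shorter chain would read, and whether an amine or a carboxylic acid could stand in place of the selenium-bearing chain end.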